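The source may hold more compounds than are shown below. What is called first, only, known or untested is meant among the compounds shown, and "the series" means these compounds.

Measured so far in a functional assay on WI-38 cells (Homo sapiens) for inhibition; on this read-out higher numbers stand for weaker inhibition and lower numbers for stronger inhibition:
Compound 1 `CCC(C)C(NC(=O)n1nnc2ccccc21)C(=O)NC(c1ccccc1)c1ccccc1` gives 62700 nM.
Compound 3 `O=C1NC(c2ccccc2)C(=O)N1Cc1ccccc1` gives 78900 nM.
Compound 2 `CC(C)C1NC(=O)N(C2CCCC2)C1=O` gives only a limit, > 100000 nM.

Compound 3 and compound 1 sit within the usual scatter of each other in this assay, so the two numbers cannot be told apart. Compound 2 supplies no number at all, only (the limit of > 100000 nM in this assay, at which 1 of the 3 values shown sits). All three compounds are weak inhibitors on this read-out.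

Compound 4 `CCC(C)C1NC(=O)N(Cc2ccccc2)C1=O` is the next compound to be measured in this assay. It differs from compound 3 in one place: sec-butyl in place of phenyl on a saturated ring carbon. Within the data shown here, no step between two measured compounds of this kind is available, so the size of this change can only be estimated. Compound 2, which also carries a small branched alkyl group on the saturated ring carbon of its five-membered ring, gives a limit rather than a number, which points toward inhibition that stays weak or grows weaker.

Compound 4 is therefore expected to give about 95000 nM in this assay, with a plausible range from 35000 nM to 250000 nM. The expected step from compound 3 to compound 4 is a 1.2-fold higher number from compound 3 to compound 4 (0.08 log units; within the scatter), toward weaker inhibition, with a fair chance that only a limit is recorded.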

Compound 4, half-maximal inhibitory concentration: 74100 nM
For compound 4 the middle estimate is 1.3-fold (0.11 log units) above the measured one; low and high end bracket the measured number.
By their numbers in this assay, from the lowest: compounds 1, 4 and 3 (each within the scatter of the next). At a limit, above all of these: compound 2.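

In this assay, among these compounds, the first step at this position reads a 1.1-fold lower number from compound 3 to compound 4 (0.03 log units; within the scatter), so sec-butyl in place of phenyl on a saturated ring carbon gives a number that cannot be told apart from the original. On this core, then, the six-membered aromatic ring at this carbon is not needed to keep the weak inhibition seen with compound 3, since a group with no ring gives a matching read-out. The data shown offer no measured property that would account for this result.

Among the compounds shown here, this single step cannot show whether the position is insensitive to every change, as it covers only two hydrocarbon groups. An amine, a carboxylic acid or a longer chain on the same carbon could leave the number unchanged or shift it beyond the scatter, and the compounds shown do not tell which.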